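Aminotriazole thioethers: ketone versus amide arms

The source may hold more compounds than are shown below. What is called first, only, known or untested is meant among the compounds shown, and "the series" means these compounds.

Compound 1 `COc1cc(-c2nnc(SCC(=O)c3ccc(Cl)cc3)n2N)cc(OC)c1OC` and compound 2 `COc1cc(-c2nnc(SCC(=O)c3ccc(C)cc3)n2N)cc(OC)c1OC` share a core and differ in one place, (methyl in place of chloro on an aromatic carbon). In a functional assay on HCT-116 cells (Homo sapiens) for antiproliferative activity, read by MTT assay, with a stated time of 48 h (on this read-out higher numbers stand for weaker inhibition and lower numbers for stronger inhibition), compound 1 gives 7500 nM. In this assay compound 2 gives 370 nM, so the step is a 20-fold lower number from compound 1 to compound 2 (1.31 log units; beyond the scatter). Compound 3 `COc1cc(-c2nnc(SCC(=O)NCc3ccc(Cl)cc3)n2N)cc(OC)c1OC` differs from compound 1 at the carbonyl carbon, ((4-chlorobenzyl)amino in place of 4-chlorophenyl on a carbonyl carbon). In this assay compound 3 reports only a limit, > 100000 nM, and not a number. The steps to it are an at least 13-fold higher number from compound 1 to compound 3 (1.12 log units; beyond the scatter) and an at least 270-fold higher number from compound 2 to compound 3 (2.43 log units; beyond the scatter); both rest on (the limit of > 100000 nM in this assay, at which 1 of the 3 values shown sits), so their true size is open. Compound 4 `COc1cc(-c2nnc(SCC(=O)NCc3ccc(C)cc3)n2N)cc(OC)c1OC` has not been measured; it differs from compound 3 as methyl in place of chloro on an aromatic carbon, the same change as that from compound 1 to compound 2, made here on the amide arm. If the step repeats, the number for compound 4 is expected to fall by about an at least 2.5-fold lower number from compound 3 to compound 4 (0.39 log units; beyond the scatter) from the limit of compound 3, though a value starting at a limit may still end at one. Compound 4 is estimated at 40000 nM, within 8000 nM to 150000 nM.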

Compound 4, half-maximal inhibitory concentration: > 100000 nM
Compound 4: a limit, no number; the forecaster's own chance of this, stated with the estimate: 50%; middle value at least 2.5-fold (0.39 log units) from the limit.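

In this assay compound 4 gives only a limit, > 100000 nM, and not a number; compound 3 also stands at a limit, so the methyl-for-chloro step on the amide arm, like any step between these two compounds, cannot be read: the limit of > 100000 nM in this assay, at which 2 of the 4 values shown sit.

Both amide compounds stay clearly apart from the ketone compounds, with an at least 270-fold higher number from compound 2 to compound 4 (2.43 log units; beyond the scatter) and an at least 13-fold higher number from compound 1 to compound 4 (1.12 log units; beyond the scatter), and the true size of both steps is open.

The change is therefore seen as a number only on the ketone arm, as a 20-fold lower number from compound 1 to compound 2 (1.31 log units; beyond the scatter), and the result neither confirms nor contradicts its carrying over to the amide arm, since a real shift could lie wholly beyond the limit.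

Still open, as far as these compounds go, is whether any amide arm on this core gives a readable number, for example a phenylamino arm or a morpholine amide. Also open, from the compounds shown here alone, is whether the ketone arm's response extends past chloro and methyl to a methoxy or a dimethylamino group at the same place on the ring.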